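A few compounds are considered here, and "the series" means these few. Any claim that something is new, unique, unknown or untested is made for them only; others in the source may bear on it.

Compound 1 `CCCCCCc1cc2cn(Cc3cn(-c4ccccc4F)nn3)c(=O)nc2o1` carries a hexyl group on the shared core and a 2-fluorophenyl group on the triazole nitrogen. In a functional assay on A549 cells (Homo sapiens) for antiproliferative activity, read by MTT assay, with a stated time of 72 h (a lower number here means a stronger inhibitor, a higher number a weaker inhibitor), compound 1 reaches only a limit, > 100000 nM. Compound 2 `CCCCCCC#Cc1c(CCCCCC)oc2nc(=O)n(Cc3cn(-c4ccc(Cl)cc4)nn3)cc12` adds an oct-1-yn-1-yl group to the core and bears a 4-chlorophenyl group on the triazole nitrogen. In this assay compound 2 likewise gives only a limit, > 100000 nM. Compound 3 `CCCCCCC#Cc1c(CCCCCC)oc2nc(=O)n(Cc3cn(Cc4ccccc4)nn3)cc12` keeps the oct-1-yn-1-yl and hexyl groups but places a benzyl group on the triazole nitrogen, and in this assay compound 3 gives 21900 nM. Among the compounds with values here, compound 3 therefore stands as the only compound with a numerical value, since the other two sit at the limit of > 100000 nM in this assay, at which 2 of the 3 values shown sit. Within the data shown here, the single measured step, an at least 4.5-fold lower number from compound 2 to compound 3 (0.65 log units; beyond the scatter), concerns the triazole substituent and not the core.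

Compound 4 `CCCCCCc1cc2cn(Cc3cn(Cc4ccccc4)nn3)c(=O)nc2o1` differs from compound 3 by hydrogen in place of oct-1-yn-1-yl on an aromatic carbon. Among the measured compounds shown here, no measured step covers this change directly. Compound 1, which also lacks the oct-1-yn-1-yl group but carries a different triazole substituent, sits at a limit, > 100000 nM. On that basis compound 4 is expected to be a weaker inhibitor than compound 3, with a step of a 3.7-fold higher number from compound 3 to compound 4 (0.56 log units; beyond the scatter) in this assay, which may well push it to a limit. The estimate for compound 4 is 80000 nM, within a range of 25000 nM to 250000 nM.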

Compound 4, half-maximal inhibitory concentration: 51000 nM
For compound 4 the middle estimate is 1.6-fold (0.20 log units) above the measured one; measured number inside the range.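

In this assay, this aromatic carbon, next to the ring atom that bears a hexyl group, now has a direct reading, a 2.3-fold higher number from compound 3 to compound 4 (0.37 log units; beyond the scatter): the change is modest, and with hydrogen in place of oct-1-yn-1-yl the benzyl compound still gives a number. The same core also allows a comparison of the triazole substituents without the oct-1-yn-1-yl group, an at least 1.9-fold lower number from compound 1 to compound 4 (0.29 log units; that floor lies within the scatter), so this step alone does not place compound 4 ahead of compound 1. Compound 1 and compound 2, which carry a substituted phenyl group directly on the triazole nitrogen, both stay at a limit of the assay and not at a number: the limit of > 100000 nM in this assay, at which 2 of the 4 values shown sit.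

On these data alone, it remains open whether a shorter alkyne such as propynyl, or an amine or a hydroxyl group, on this aromatic carbon would give a value nearer that of compound 3 or that of compound 4. As far as these compounds go, the effect of a phenethyl group on the triazole nitrogen, and of a shorter chain in place of the hexyl group, also remains open.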